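This account rests on a few compounds, and the source may have more. Where it says the series, first, only, none or still open, it means among the compounds named here.

For the measured compounds named here, in a functional assay on Huh-7 cells (Homo sapiens) for inhibition, read by MTT assay, with a stated time of 48 h (on this read-out higher numbers stand for weaker inhibition and lower numbers for stronger inhibition), compound 2 `COc1ccc2c(=O)c(/C=C/C(=O)NCc3cccc(F)c3)coc2c1` gives 10100 nM, the only number among the three compounds measured. Compound 1 `COc1ccc2c(=O)c(/C=C/C(=O)Nc3ccc(C)cc3)coc2c1` reaches only a limit there, > 100000 nM. Compound 3 `Cc1ccc(CNC(=O)/C=C/c2coc3cc(O)ccc3c2=O)cc1` likewise reaches only a limit, > 100000 nM. Going by the values given here, the one measured step, an at least 9.9-fold lower number from compound 1 to compound 2 (0.99 log units; beyond the scatter), was at least modest, and the limit of > 100000 nM in this assay, at which 2 of the 3 values shown sit, leaves little room for comparison. Compound 4 `COc1ccc2c(=O)c(/C=C/C(=O)NCc3ccccc3)coc2c1` differs from compound 2 by hydrogen in place of fluoro on an aromatic carbon. Among the compounds with values here, no measured step removes a fluoro alone; the step from compound 1 to compound 2 changed the whole amide substituent, so it bears on this change only loosely. Compound 4 is therefore expected to sit close to compound 2, with an expected step of a 1.5-fold higher number from compound 2 to compound 4 (0.17 log units; within the scatter) not beyond the scatter. Compound 4 is estimated at 15000 nM, within 5000 nM to 50000 nM.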

Compound 4, half-maximal inhibitory concentration: 13600 nM
Beside the measured number, compound 4's estimate is 1.1-fold (0.04 log units) above it; low and high end bracket the measured number.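

In this assay, hydrogen in place of fluoro on this aromatic carbon gives a 1.3-fold higher number from compound 2 to compound 4 (0.13 log units; within the scatter), so the two groups cannot be told apart at this place. Benzyl in place of 4-methylphenyl on the amide nitrogen still gives an at least 7.3-fold lower number from compound 1 to compound 4 (0.86 log units; beyond the scatter), so the lower number seen earlier with 3-fluorobenzyl does not depend on the fluoro. Compound 1 stands at a limit, so this step is a bound and not an exact size: the limit of > 100000 nM in this assay, at which 2 of the 4 values shown sit.

On these data alone, whether a methoxy group, a trifluoromethyl group or an amine at this place would move the number beyond the scatter stays open. So does the effect of a longer chain between the amide nitrogen and the aromatic ring.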